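The source may report more compounds than this note shows. Statements on the series, on what has been measured and on what is new or still open speak of the compounds shown alone.

Three members of the series have been measured in an assay on isolated protein for inhibition of Amine oxidase [flavin-containing] B (Homo sapiens); a higher number here means a weaker inhibitor, a lower number a stronger inhibitor. Compound 1 `C#CCNC1CCc2c(SCCc3cccc(C)c3)cccc21` gives 0.35 nM. Compound 2 `C#CCNC1CCc2c(SCCc3ccc(C)cc3)cccc21` gives 25800 nM, and compound 3 `C#CCNC1CCc2c(SCCc3ccc(Cl)cc3)cccc21` gives 10800 nM. Compound 3 therefore stands second highest of the three numbers: the step from compound 2 to compound 3 is a 2.4-fold lower number from compound 2 to compound 3 (0.38 log units; beyond the scatter), whereas the step from compound 1 to compound 3 is a 31000-fold higher number from compound 1 to compound 3 (4.49 log units; beyond the scatter).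

Compound 4 `C#CCNC1CCc2c(SCCc3cccc(Br)c3)cccc21` is the next entry, and its change from compound 3 is 3-bromophenyl in place of 4-chlorophenyl on a saturated chain carbon, two bonds along the chain from a sulfur. Among the compounds with values here, two measured steps bear on it. Going from compound 1 to compound 2 gave a 74000-fold higher number from compound 1 to compound 2 (4.87 log units; beyond the scatter), and going from compound 1 to compound 3 gave a 31000-fold higher number from compound 1 to compound 3 (4.49 log units; beyond the scatter); both steps replace the 3-methylphenyl of compound 1 with a 4-methylphenyl or a 4-chlorophenyl. Within the data shown here, compound 4 returns to a 3-substituted ring, now as 3-bromophenyl, so a large drop in number from compound 3 is expected in this assay, in the direction of compound 1, though bromo in that ring has no measured precedent here and the step from compound 2 to compound 3 shows chloro and methyl differing only modestly. The expected step from compound 3 to compound 4 is a 3600-fold lower number from compound 3 to compound 4 (3.56 log units; beyond the scatter). Compound 4 is estimated at 3 nM, within a range of 0.2 nM to 100 nM.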

Compound 4, half-maximal inhibitory concentration: 30500 nM
Beside the measured number, compound 4's estimate is 10000-fold (4.01 log units) below it, outside the stated range (above it).
By their numbers in this assay, from the lowest: compound 1; then compound 3; then compounds 2 and 4 (each within the scatter of the next).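

In this assay, a 3-substituted ring alone does not bring the low number back: compound 1 and compound 4 differ only in methyl against bromo on that ring, yet the change gives an 87000-fold higher number from compound 1 to compound 4 (4.94 log units; beyond the scatter). Against the 4-substituted rings, the 3-bromophenyl gives a 2.8-fold higher number from compound 3 to compound 4 (0.45 log units; beyond the scatter) and a 1.2-fold higher number from compound 2 to compound 4 (0.07 log units; within the scatter), so among these four only compound 1, with its 3-methylphenyl, has a low number. No supporting evidence bears on the size of the methyl-to-bromo step.

Open, from the compounds shown here alone, is whether the low number is confined to the 3-methylphenyl or extends to other rings at this position, such as 3-chlorophenyl, 3-ethylphenyl or 3-methoxyphenyl. Also open, going by these compounds, is whether a longer chain to the sulfur would keep the difference between compound 1 and compound 4.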